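The source may report more compounds than this note shows. Statements on the series, on what has been measured and on what is new or still open speak of the compounds shown alone.

Values in a functional assay on NCI-H460 cells (Homo sapiens) for antiproliferative activity, read by MTT assay, with a stated time of 48 h; on this read-out lower numbers stand for stronger inhibition and higher numbers for weaker inhibition

- compound 1 (`COc1cc(-c2cccc3nc(-c4ccc(F)cc4)oc23)cc(OC)c1OC`) gives 8700 nM on the 4-fluorophenyl member
- compound 2 (`COc1cc(-c2cccc3nc(-c4ccc(C)cc4)oc23)cc(OC)c1OC`) gives 1900 nM on the 4-methylphenyl member
- compound 3 (`COc1cc(-c2cccc3nc(-c4cccc(O)c4)oc23)cc(OC)c1OC`) gives 1900 nM on the 3-hydroxyphenyl member

Compound 3 stands level with compound 2, and these two share the lowest number of the three, with compound 1 furthest away. The next member is compound 4 (`COc1cc(-c2cccc3nc(-c4cccs4)oc23)cc(OC)c1OC`), and the change is thiophen-2-yl in place of 3-hydroxyphenyl on an aromatic carbon in short, thiophen-2-yl in place of 3-hydroxyphenyl. The measured swaps at this place are modest or absent (a 4.6-fold lower number from compound 1 to compound 3 (0.66 log units; beyond the scatter); no change at the digits printed from compound 2 to compound 3 (within the scatter)), and the change within the group is of similar size (a 4.6-fold lower number from compound 1 to compound 2 (0.66 log units; beyond the scatter)). Going by the values given here, no measured compound carries thiophen-2-yl, so the data give no direct reading for it. Among the compounds with values here, a small move towards a higher number is expected in this assay, since compound 1 (8700 nM) is the only value apart from the level shared by compound 2 and compound 3. The expected step is small (a 1.8-fold higher number from compound 3 to compound 4 (0.27 log units; within the scatter)). Compound 4 is estimated at 3500 nM (expected range 1200 nM to 10000 nM).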

Compound 4, half-maximal inhibitory concentration: 1600 nM
Compound 4: the middle estimate sits 2.2-fold (0.34 log units) above what was measured; the measured number falls inside the stated range.
By their numbers in this assay, from the lowest: compounds 4, 2 and 3 (each within the scatter of the next); then compound 1.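

In this assay, this place on the five-membered aromatic ring with 1 nitrogen and 1 oxygen accepts a five-membered aromatic ring with 1 hetero atom without leaving the level of the six-membered aromatic members, with a 1.2-fold lower number from compound 3 to compound 4 (0.07 log units; within the scatter) and a 1.2-fold lower number from compound 2 to compound 4 (0.07 log units; within the scatter). Loss of the hydrogen-bond donor of compound 3 therefore does not move the number beyond the scatter, while a 5.4-fold lower number from compound 1 to compound 4 (0.74 log units; beyond the scatter) leaves compound 1 as the one value apart among the four. No measured evidence bears on the origin of these values.

On these data alone, whether a non-aromatic group such as cyclohexyl, or a phenyl carrying an amine or a carboxylic acid, would hold this level remains open. The step from compound 3 to compound 4 also changes ring size and donor count together, so their separate contributions cannot be told apart.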